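Shifting the halogen pattern on the benzamide ring

The source may hold more compounds than are shown below. What is called first, only, known or untested is meant among the compounds shown, and "the series" means these compounds.

Of the compounds shown here, three of one core have been measured so far. In a functional assay on HepG2 cells (Homo sapiens) for inhibition, read by MTT assay (on this read-out lower numbers stand for stronger inhibition and higher numbers for weaker inhibition), compound 1 `COc1cc2ncnc(Nc3ccc(NC(=O)c4ccc(C(C)(C)C)cc4)cc3)c2cc1OC` gives only a limit, > 100000 nM. That reading is the limit of > 100000 nM in this assay, at which 1 of the 3 values shown sits. Compound 2 `COc1cc2ncnc(Nc3ccc(NC(=O)c4ccccc4Cl)cc3)c2cc1OC` gives 26000 nM in this assay, and compound 3 `COc1cc2ncnc(Nc3ccc(NC(=O)c4ccc(Cl)cc4)cc3)c2cc1OC` gives 28000 nM. Compound 2 is thus one of the two compounds with a number; it sits together with compound 3, since a 1.1-fold higher number from compound 2 to compound 3 (0.03 log units; within the scatter) is within the scatter, so neither is set apart from the other. Against compound 1, both steps are clear: an at least 3.8-fold lower number from compound 1 to compound 2 (0.58 log units; beyond the scatter) and an at least 3.5-fold lower number from compound 1 to compound 3 (0.55 log units; beyond the scatter).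

Compound 4 `COc1cc2ncnc(Nc3ccc(NC(=O)c4c(F)cccc4F)cc3)c2cc1OC` is the next step from compound 2: 2,6-difluorophenyl in place of 2-chlorophenyl on a carbonyl carbon. Within the data shown here, of the measured steps, the one from compound 2 to compound 3 bears most on it, as it also reshuffles a halogen on the same ring and gave a 1.1-fold higher number from compound 2 to compound 3 (0.03 log units; within the scatter), a change within the scatter. The larger steps from compound 1 involve a tert-butyl, which compound 4 does not carry. He therefore expects no step beyond the scatter in this assay, with a 1.1-fold higher number from compound 2 to compound 4 (0.03 log units; within the scatter). His estimate for compound 4 is 28000 nM, within 10000 nM to 80000 nM.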

Compound 4, half-maximal inhibitory concentration: 17000 nM
Compound 4: middle estimate off by 1.6-fold (0.22 log units), on the high side; low and high end bracket the measured number.
By their numbers in this assay, from the lowest: compounds 4, 2 and 3 (each within the scatter of the next). At a limit, above all of these: compound 1.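

In this assay, the substituted phenyl on the carbonyl carbon takes a further kind of halogen pattern without any step beyond the scatter: a 1.5-fold lower number from compound 2 to compound 4 (0.18 log units; within the scatter) and a 1.6-fold lower number from compound 3 to compound 4 (0.22 log units; within the scatter). What the earlier pair showed only for moving one chlorine now also holds for 2,6-difluorophenyl, which changes both the halogen and how many the ring carries, so no halogen pattern among compounds 2, 3 and 4 is set apart from the others. The contrast with the 4-(tert-butyl)phenyl group also extends to a fluorinated ring, with an at least 5.8-fold lower number from compound 1 to compound 4 (0.76 log units; beyond the scatter), although compound 1 is a limit and this step therefore gives only a bound: the limit of > 100000 nM in this assay, at which 1 of the 4 values shown sits.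

The compounds shown leave open whether this level response belongs to halogens as such, as the only ring without a halogen is the one carrying tert-butyl. As far as these compounds go, it also remains open how the series would respond to a methyl group, which could show whether a small alkyl group falls with the halogens or with tert-butyl, or to an amine or a carboxylic acid on the same ring.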